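Sulfur-linked side chain variation on the shared core

The source may report more compounds than this note shows. Statements on the series, on what has been measured and on what is new or still open speak of the compounds shown alone.

Three measured compounds share one core and differ only on a saturated chain carbon bound to a sulfur. In an ADME assay on GES1 cells (Homo sapiens) for inhibition, read by MTT assay, with a stated time of 72 h (on this read-out lower numbers stand for stronger inhibition and higher numbers for weaker inhibition), compound 1 `Cc1cc(Nc2cc(-c3ccccc3)[nH]n2)n2nc(SCCc3ccccc3)nc2n1` gives 37400 nM. Compound 2 `Cc1cc(Nc2cc(-c3ccccc3)[nH]n2)n2nc(SCc3ccccc3Br)nc2n1` gives 41100 nM and compound 3 `C#CCSc1nc2nc(C)cc(Nc3cc(-c4ccccc4)[nH]n3)n2n1` gives 45700 nM; the three numbers sit close together, with the step of a 1.1-fold higher number from compound 1 to compound 2 (0.04 log units; within the scatter), the step of a 1.2-fold higher number from compound 1 to compound 3 (0.09 log units; within the scatter) and the step of a 1.1-fold higher number from compound 2 to compound 3 (0.05 log units; within the scatter) all small. Compound 4 `Cc1ccc(CSc2nc3nc(C)cc(Nc4cc(-c5ccccc5)[nH]n4)n3n2)cc1` has not yet been measured. Against compound 1 it carries 4-methylphenyl in place of benzyl on a saturated chain carbon bound to a sulfur. All three measured steps bear on this change, since each swaps a group at the same saturated chain carbon bound to a sulfur, and none of them shifted the number beyond the scatter. The expected step is therefore a 1.0-fold higher number from compound 1 to compound 4 (0.01 log units; within the scatter), with no movement beyond the scatter anticipated in either direction. The value of compound 4 is estimated at 38000 nM, within a range from 19000 nM to 76000 nM.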

Compound 4, half-maximal inhibitory concentration: 36200 nM
Compound 4: middle estimate off by 1.0-fold (0.02 log units), on the high side; the range from low to high includes it.
By their numbers in this assay, from the lowest: compounds 4, 1, 2 and 3 (each within the scatter of the next).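

The same atoms joined differently, with 4-methylphenyl in place of benzyl on a saturated chain carbon bound to a sulfur, give no readable change in this assay, with a 1.0-fold lower number from compound 1 to compound 4 (0.01 log units; within the scatter) as the step. The flat picture also holds against the other two side chains, with a 1.3-fold lower number from compound 3 to compound 4 (0.10 log units; within the scatter) and a 1.1-fold lower number from compound 2 to compound 4 (0.06 log units; within the scatter) as the steps, so a methyl on the side-chain ring, found only in compound 4, leaves it within the scatter of compounds 1, 2 and 3. Nothing available explains this lack of response at the position.

On these data alone, whether any group at this carbon can move the number beyond the scatter remains open. A side chain ending in an amine or a carboxylic acid, or a longer chain, would test this.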